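This account rests on a few compounds, and the source may have more. Where it says the series, first, only, none or still open, it means among the compounds named here.

In a functional assay on blood (Homo sapiens), with a stated time of 60 min, in the presence of a further agent that is not named here (on this read-out lower numbers stand for an effect already at smaller amounts and higher numbers for an effect only at larger amounts of compound), three compounds share a core and differ in one group on a saturated ring carbon. Compound 1 `O=C(O)C1(S(=O)(=O)c2ccc(Oc3ccc(OC(F)(F)F)cc3)cc2)CCC2(CCNCC2)C1`, with carboxy, gives 1800 nM. Compound 2 `O=S(=O)(c1ccc(Oc2ccc(OC(F)(F)F)cc2)cc1)C1(CO)CCC2(CCNCC2)C1`, with hydroxymethyl, gives > 15000 nM, which is a limit of the assay. Compound 3 `NC(=O)C1(S(=O)(=O)c2ccc(Oc3ccc(OC(F)(F)F)cc3)cc2)CCC2(CCNCC2)C1`, with carbamoyl, gives 3700 nM, the higher of the two actual numbers. Compound 4 `O=C(Nc1ccccc1O)C1(S(=O)(=O)c2ccc(Oc3ccc(OC(F)(F)F)cc3)cc2)CCC2(CCNCC2)C1` has 2-hydroxyphenyl in place of hydrogen on the amide-type nitrogen of compound 3: 2-hydroxyphenyl in place of hydrogen on an amide-type nitrogen. The measured changes at this carbon are a 2.1-fold higher number from compound 1 to compound 3 (0.31 log units; beyond the scatter) and an at least 4.0-fold lower number from compound 2 to compound 3 (0.60 log units; beyond the scatter). Neither adds a ring, so they guide the size only loosely and give no firm direction. The expected change is a 1.2-fold lower number from compound 3 to compound 4 (0.09 log units; within the scatter). Compound 4 is estimated at 3000 nM, with an expected range of 800 nM to 12000 nM.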

Compound 4, half-maximal effective concentration: > 15000 nM
Compound 4 was reported as a limit; the forecaster's own chance of this, stated with the estimate: 15%; at least 5.0-fold (0.69 log units) between middle value and limit.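

Placing 2-hydroxyphenyl on the amide-type nitrogen is the only change shown that brings a ring into the group on this carbon, and in this assay it gives an at least 4.0-fold higher number from compound 3 to compound 4 (0.60 log units; beyond the scatter) and an at least 8.3-fold higher number from compound 1 to compound 4 (0.92 log units; beyond the scatter). So this position does not accept every larger group on that nitrogen: carboxy and carbamoyl both give measurable numbers, whereas compound 4 reaches only a limit. The step between compound 2 and compound 4 cannot be read, with both compounds at a limit: the limit of > 15000 nM in this assay, at which 2 of the 4 values shown sit.

Going by these compounds, it remains open whether the ring or its hydroxy group drives this change. Plain phenyl or a small methyl on the same nitrogen would help separate the two.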